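The source may report more compounds than this note shows. Statements on the series, on what has been measured and on what is new or still open speak of the compounds shown alone.

Measured so far:
compound 1, `O=S(=O)(NCCCNCc1ccccc1Cl)c1cc(C(F)(F)F)cc(C(F)(F)F)c1`: 20000 nM
compound 2, `O=S(=O)(NCCNCc1ccc(-c2ccccc2)cc1)c1cc(C(F)(F)F)cc(C(F)(F)F)c1`: 2700 nM

In a functional assay on HT-29 cells (Homo sapiens) for inhibition, read by MTT assay, with a stated time of 72 h (on this read-out lower numbers stand for stronger inhibition of growth and higher numbers for weaker inhibition of growth), compound 1 gives 20000 nM, the higher of the two numbers obtained. Compound 2 gives 2700 nM, a lower number, and the gap between the two lies beyond the usual scatter of the read-out. Compound 2 differs from compound 1 in more than one place, so its value shows only where compound 1 stands among the measured compounds, not what any single change contributes.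

Compound 3, `O=S(=O)(NCCCNCc1ccc(C(F)(F)F)cc1)c1cc(C(F)(F)F)cc(C(F)(F)F)c1`, has not yet been measured. It departs from compound 1 by one change: 4-(trifluoromethyl)phenyl in place of 2-chlorophenyl on a saturated chain carbon bound to an amine nitrogen. For the measured compounds named here, no measured pair shows this change on its own, so the data do not fix its size. The expected step is a 2.0-fold lower number from compound 1 to compound 3 (0.30 log units; within the scatter), a modest move toward a lower number, and it may turn out to be no step beyond the scatter at all. Compound 3 is expected to give about 10000 nM in this assay. The estimated range for compound 3 runs from 3000 nM to 30000 nM, with the upper end reflecting the possibility that it stays close to compound 1.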

Compound 3, concentration for 50% growth inhibition: 2900 nM
Compound 3: middle estimate off by 3.4-fold (0.54 log units), on the high side; the measured number lies below the stated range.
By their numbers in this assay, from the lowest: compounds 2 and 3 (each within the scatter of the next); then compound 1.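

In this assay, the exchange of 2-chlorophenyl for 4-(trifluoromethyl)phenyl on a saturated chain carbon bound to an amine nitrogen gives a 6.9-fold lower number from compound 1 to compound 3 (0.84 log units; beyond the scatter). For the compounds shown here, this is the first reading of a single change, and it shows that the group at this place can shift growth inhibition beyond the scatter, which the earlier gap between compounds differing in more than one place could not show. The pair reads the exchange of 2-chlorobenzyl to 4-(trifluoromethyl)benzyl only as a whole, and no measurement at hand bears on the reason for the step.

The compounds shown leave open how much of the step goes with the loss of chlorine and how much with the arrival of trifluoromethyl, a question that a plain phenyl at this place would help to settle. They also leave open whether the same exchange gives a similar step on a shorter or longer chain, and how other groups on the ring, such as a methoxy group or a bromine, would read at this place.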